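A few compounds are considered here, and "the series" means these few. Any claim that something is new, unique, unknown or untested is made for them only; others in the source may bear on it.

Measured compounds: compound 1 `COc1ccc(-c2nc(C(=O)/C=C\Nc3ccc(Cl)cc3)c3ccccn23)cc1` and compound 2 `COc1ccc(N/C=C\C(=O)c2nc(-c3ccc(OC)cc3)n3ccccc23)cc1`.

In a functional assay on HCT-116 cells (Homo sapiens) for cytotoxicity, read by MTT assay, with a stated time of 48 h (a higher number here means a weaker inhibitor, a lower number a stronger inhibitor), compound 1 gives a limit of the assay, > 30000 nM. Compound 2 likewise gives only a limit in this assay, > 30000 nM. The step from compound 1 to compound 2 (a step that the two limits leave unreadable from compound 1 to compound 2) cannot be sized because of the limit of > 30000 nM in this assay, at which 2 of the 2 values shown sit. Compound 3 `O=C(/C=C\Nc1ccc(Cl)cc1)c1nc(-c2ccc(F)cc2)n2ccccc12` differs from compound 1 by fluoro in place of methoxy on an aromatic carbon. Among the measured compounds shown here, no measured step bears on this change in this assay, and compound 1 stands at a limit, so no direction beyond the scatter can be read. Compound 3 is expected to give 40000 nM (range 10000 nM to 200000 nM), the expected step being a step that the limit leaves unreadable from compound 1 to compound 3.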

Compound 3, half-maximal inhibitory concentration: 1210 nM
Compound 3: the middle estimate sits 33-fold (1.52 log units) above what was measured; measured number outside the range, below it.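

In this assay, fluoro in place of methoxy gives an at least 24-fold lower number from compound 1 to compound 3 (1.39 log units; beyond the scatter), the only step among these compounds that can be sized. The other step cannot be read, as both of its compounds stand at a limit: the limit of > 30000 nM in this assay, at which 2 of the 3 values shown sit.

This place, on an aromatic carbon para to a large group, therefore responds to the change when chloro is kept elsewhere in the molecule. Going by these compounds, whether fluoro acts the same way with the methoxy carried by compound 2 stays open. So does what an amine or a carboxylic acid would give at this place.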